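The source may hold more compounds than are shown below. What is called first, only, known or untested is meant among the compounds shown, and "the series" means these compounds.

The study places four closely related peptide-like compounds in an ADME assay on Vero C1008 cells (Chlorocebus sabaeus) for cytotoxicity, read by luminescence and CellTiter-Glo, with a stated time of 24 h; on this read-out higher numbers stand for lower toxicity in this test and lower numbers for higher toxicity in this test. Compound 1 `CC(C)C[C@H](NC(=O)OCc1cccc(F)c1)C(=O)N[C@H](C=O)C[C@@H]1CCNC1=O` and compound 2 `CC(C)C[C@H](NC(=O)OCCc1cccc(Cl)c1)C(=O)N[C@H](C=O)C[C@@H]1CCNC1=O` share one core and differ only in 3-chlorobenzyl in place of 3-fluorophenyl on a saturated chain carbon bound to an oxygen next to a carbonyl group. In this assay compound 1 gives > 200000 nM, which is a limit of the measurement rather than a number. In this assay compound 2 likewise gives > 200000 nM, again a limit. The step that the two limits leave unreadable from compound 1 to compound 2 therefore cannot be read, because both values sit at the limit of > 200000 nM in this assay, at which 3 of the 3 values shown sit. Compound 3 `O=C(N[C@@H](CC1CC1)C(=O)N[C@@H](C[C@@H]1CCNC1=O)C(O)S(=O)(=O)O)OCc1cccc(F)c1` rests on a second core; the difference between the two cores is not broken down here. In this assay compound 3 gives > 200000 nM, once more a limit. Compound 4 `O=C(N[C@@H](CC1CC1)C(=O)N[C@@H](C[C@@H]1CCNC1=O)C(O)S(=O)(=O)O)OCCc1cccc(Cl)c1` arises from compound 3 by the same change as before, (3-chlorobenzyl in place of 3-fluorophenyl on a saturated chain carbon bound to an oxygen next to a carbonyl group). Because every measured value sits at the limit of > 200000 nM in this assay, at which 3 of the 3 values shown sit, the earlier step offers no readable size to carry over. Compound 4 is expected to show a step that the limit leaves unreadable from compound 3 to compound 4. Compound 4 is thus estimated at 250000 nM, most probably reported again as a limit, in a range from 100000 nM to 1000000 nM.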

Compound 4, half-maximal cytotoxic concentration: > 200000 nM
Compound 4: a limit, no number; the forecaster's own chance of this, stated with the estimate: 85%; the middle value is on the limit's open side.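

In this assay compound 4 gives > 200000 nM, which is a limit and not a number. No size can be read for the change from compound 3 to compound 4, as all the compounds rest at one value: the limit of > 200000 nM in this assay, at which 4 of the 4 values shown sit. The compounds shown leave open at what concentration any of them would become toxic in this assay, and whether this change alters that concentration at all.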